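A few compounds are considered here, and "the series" means these few. Any claim that something is new, unique, unknown or untested is made for them only; others in the source may bear on it.

Notes on the series, read in an ADME assay on microsomes from liver (Homo sapiens) for metabolic stability; on this read-out lower numbers stand for a shorter-lived compound and higher numbers for a longer-lived compound. Compound 3 `CC(C)C(c1ncco1)c1ccc(-c2ccc3cccc(F)c3c2)[nH]c1=O` gives 0.178 h and compound 1 `CC(C)C(Cc1ncc[nH]1)c1ccc(-c2ccc3cccc(F)c3c2)[nH]c1=O` gives 0.106 h. The step of a 1.7-fold higher number from compound 1 to compound 3 (0.23 log units; within the scatter) lies within the scatter, so these two values cannot be told apart. Compound 2 `CC(C)C(Nc1nnc[nH]1)c1ccc(-c2ccc3cccc(F)c3c2)[nH]c1=O` reads > 3 h, which is a limit and not a number.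

Compound 4 `CC(C)C(Cc1nnc[nH]1)c1ccc(-c2ccc3cccc(F)c3c2)[nH]c1=O` follows from compound 3 by the change ((4H-1,2,4-triazol-3-yl)methyl in place of 1,3-oxazol-2-yl on a saturated chain carbon bound to an aromatic carbon and a saturated chain carbon), with (4H-1,2,4-triazol-3-yl)methyl in place of 1,3-oxazol-2-yl on a saturated chain carbon bound to an aromatic carbon and a saturated chain carbon. The 4H-1,2,4-triazol-3-yl ring is shared with compound 2, and the large step of an at least 16-fold lower number from compound 2 to compound 3 (1.22 log units; beyond the scatter) points to a rise on that ring. The methyl is shared with compound 1, however, and the step of an at least 28-fold higher number from compound 1 to compound 2 (1.45 log units; beyond the scatter) changes ring and amino together, so the data do not separate the two. Only part of that large gain is therefore expected to carry over. The estimated step is a 2.8-fold higher number from compound 3 to compound 4 (0.45 log units; beyond the scatter), a moderate rise. For compound 4 the expected value is 0.5 h, with an estimated range of 0.15 h to 2 h.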

Compound 4, half-life: 0.307 h
For compound 4 the middle estimate is 1.6-fold (0.21 log units) above the measured one; the range from low to high includes it.
By their numbers in this assay, from the lowest: compounds 1, 3 and 4 (each within the scatter of the next, the first and the last beyond it). At a limit, above all of these: compound 2.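

With the 4H-1,2,4-triazol-3-yl ring held constant, exchanging amino for methyl in this assay gives an at least 9.7-fold lower number from compound 2 to compound 4 (0.98 log units; beyond the scatter), so the larger part of the earlier gain follows the amino and not the ring. With methyl held constant, the ring exchange alone gives a 2.9-fold higher number from compound 1 to compound 4 (0.46 log units; beyond the scatter), a modest rise that sets the share of the ring apart, while a 1.7-fold higher number from compound 3 to compound 4 (0.24 log units; within the scatter) leaves these two compounds indistinguishable. Compound 2 stands at a limit and not at a number: the limit of > 3 h in this assay, at which 1 of the 4 values shown sits.

The compounds shown leave open whether amino brings a similar gain on the 1H-imidazol-2-yl or 1,3-oxazol-2-yl ring. Going by these compounds, it is also open whether an ether oxygen or a methylamine in the same place would keep the longer half-life.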